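A Dimethoxyphenyl Swap Carried onto a Second Core

This account rests on a few compounds, and the source may have more. Where it says the series, first, only, none or still open, it means among the compounds named here.

Compound 1 `N#Cc1ccc(/C=C2\CN(S(=O)(=O)c3ccc(F)cc3)C/C(=C\c3ccccc3F)C2=O)cc1` and compound 2 `COc1cc(/C=C2\CN(S(=O)(=O)c3ccc(F)cc3)C/C(=C\c3ccccc3F)C2=O)cc(OC)c1` share one core. In a functional assay on HepG2 cells (Homo sapiens) for cytotoxicity, read by MTT assay, with a stated time of 24 h (on this read-out lower numbers stand for stronger inhibition and higher numbers for weaker inhibition), compound 1 gives 8180 nM, and in this assay compound 2 gives 9300 nM. The two structures differ by the change (3,5-dimethoxyphenyl in place of 4-cyanophenyl on a double-bonded chain carbon bound to a double-bonded ring carbon), and that change made the step of a 1.1-fold higher number from compound 1 to compound 2 (0.06 log units; within the scatter), so the two numbers sit within the scatter of each other and no order can be read between them.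

Compound 3 `COc1cc(/C=C2\CN(S(=O)(=O)c3ccc(NC(C)=O)cc3)C/C(=C\c3ccc(C#N)cc3)C2=O)cc(OC)c1OC` is built on a different core; the difference between the two cores is not broken down here. In this assay compound 3 gives 2890 nM, the lowest of the three numbers, with its steps to compound 1 and to compound 2 both lying beyond the scatter.

Compound 4 `COc1cc(/C=C2\CN(S(=O)(=O)c3ccc(NC(C)=O)cc3)C/C(=C\c3cc(OC)c(OC)c(OC)c3)C2=O)cc(OC)c1` has not yet been measured. For the measured compounds named here, it differs from compound 3 by the change (3,5-dimethoxyphenyl in place of 4-cyanophenyl on a double-bonded chain carbon bound to a double-bonded ring carbon), which is the same change as the one from compound 1 to compound 2, made at the same place. The expected step of a 1.1-fold higher number from compound 3 to compound 4 (0.04 log units; within the scatter) rests on the earlier step of a 1.1-fold higher number from compound 1 to compound 2 (0.06 log units; within the scatter), which stayed within the scatter, and on the change occurring only twice among these compounds. Because compound 3 gives 2890 nM in this assay, compound 4 is expected to give about 3200 nM, estimated to fall between 1500 nM and 7000 nM.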

Compound 4, half-maximal inhibitory concentration: 4140 nM
For compound 4 the middle estimate is 1.3-fold (0.11 log units) below the measured one, within the range that was stated.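

In this assay the replacement of 4-cyanophenyl by 3,5-dimethoxyphenyl gave a 1.4-fold higher number from compound 3 to compound 4 (0.16 log units; within the scatter), so on the core of compound 3, as on the core of compound 1, the numbers for the two groups cannot be told apart. Set side by side, the two steps do not differ: the same change on two cores in this assay, a 1.1-fold higher number (0.06 log units; within the scatter) from compound 1 to compound 2 and a 1.4-fold higher number (0.16 log units; within the scatter) from compound 3 to compound 4, 1.3-fold (0.10 log units) apart, within the scatter of two such steps. For the compounds shown here, this shows that the change stayed inside the scatter on both of these cores, but it rests on only two pairs in a single cell assay, so it does not show that the change would carry over to any further core, and it gives no reason why the two groups read alike.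

From the compounds shown here alone, it remains open whether a different group at this place, such as an amine or a carboxylic acid on the phenyl ring, or a longer chain in place of the ring, would also stay within the scatter of 4-cyanophenyl. Going by these compounds, it is also open whether the same replacement would stay within the scatter on a core with an amine in place of the fluorine or the acetylamino group on the sulfonyl-bound ring.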